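The source may hold more compounds than are shown below. What is called first, only, known or untested is meant among the compounds shown, and "the series" means these compounds.

Measured compounds in a functional assay on HeLa cells (Homo sapiens) for cytotoxicity, read by MTT assay, with a stated time of 72 h; a higher number here means a weaker inhibitor, a lower number a stronger inhibitor:
Compound 1 `O=C(NCCO)c1cc2ccc(OCc3ccccc3)cc2oc1=O` gives 14200 nM.
Compound 2 `O=C(Nc1ccccc1)c1cc2ccc(OCc3ccccc3)cc2oc1=O` gives only the limit > 100000 nM.
Compound 3 `CCCOc1ccc2cc(C(=O)NN)c(=O)oc2c1` gives only the limit > 100000 nM.

Compound 3 stands at the limit of this assay, not at a number; the same limit holds for two of the three values shown (the limit of > 100000 nM in this assay, at which 2 of the 3 values shown sit). Compound 1 alone gives a number in this assay. Among the compounds with values here, the only measured step, an at least 7.0-fold higher number from compound 1 to compound 2 (0.84 log units; beyond the scatter), concerns the amide-type nitrogen and leaves the oxygen on the aromatic ring untouched.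

Compound 4 `NNC(=O)c1cc2ccc(OCc3ccccc3)cc2oc1=O` differs from compound 3 by phenyl in place of ethyl on a saturated chain carbon bound to an oxygen on an aromatic ring. Within the data shown here, no measured step touches this position, so the direction of the change is open. Compound 1 carries the same benzyl group on the oxygen on the aromatic ring as compound 4 and gives a number in this assay, so a number is possible. Against that, compound 3 sits at the limit. The step expected is an at least 1.6-fold lower number from compound 3 to compound 4 (0.22 log units; that floor lies within the scatter), with a fair chance that compound 4 also returns only a limit. The estimate for compound 4 is 60000 nM, range 15000 nM to 200000 nM.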

Compound 4, half-maximal inhibitory concentration: > 100000 nM
Compound 4 ended at the assay's limit; the forecaster's own chance of this, stated with the estimate: 50%; middle value at least 1.6-fold (0.22 log units) away from the limit.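

Benzyl on the oxygen on the aromatic ring is therefore not enough for a number in this assay: with amino on the amide-type nitrogen in place of 2-hydroxyethyl, the result is an at least 7.0-fold higher number from compound 1 to compound 4 (0.84 log units; beyond the scatter). The steps to compound 4 from compound 2 and from compound 3 cannot be read, so any effect of propyl to benzyl at this position remains hidden. Among the compounds shown, only compound 1, with 2-hydroxyethyl on the amide-type nitrogen, gives a number, and the rest of the series gives no size to compare: the limit of > 100000 nM in this assay, at which 3 of the 4 values shown sit.

Open, going by these compounds, is whether the number for compound 1 depends on the hydroxyl of 2-hydroxyethyl or on the chain itself; a 2-methoxyethyl or a plain ethyl group on the amide-type nitrogen would separate the two. Also open, on these data alone, is whether propyl on the oxygen on the aromatic ring gives a number when 2-hydroxyethyl sits on the amide-type nitrogen.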